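The compounds below may be only part of what the source reports. "The series", "measured", "known", "first", "only" and "open" are said of these compounds alone.

Compound 1 `COc1cc(NC(C)CCCNC(=O)Nc2cccc(F)c2)c2ncccc2c1`: 18000 nM
Compound 2 `COc1cc(NC(C)CCCNC(=O)Nc2cccc(O)c2)c2ncccc2c1`: 48000 nM

In a functional assay on HeLa cells (Homo sapiens) for inhibition, read by MTT assay, with a stated time of 72 h (a lower number here means a stronger inhibitor, a higher number a weaker inhibitor), compound 2 gives 48000 nM, the higher of the two numbers. Compound 3 `COc1cc(NC(C)CCCNC(=O)NNC(=O)Nc2cccc(F)c2)c2ncccc2c1` carries ((3-fluorophenyl)carbamoyl)amino in place of 3-hydroxyphenyl on an amide-type nitrogen. Within the data shown here, the only measured step that bears on this is a 2.7-fold higher number from compound 1 to compound 2 (0.43 log units; beyond the scatter), modest and beyond the scatter, with hydroxy in place of fluoro on an aromatic carbon. Among the measured compounds shown here, compound 3 has fluoro again, but no measured step covers the added carbamoylamino unit, so the reading is uncertain. A modest move to a lower number in this assay is expected, estimated as a 2.2-fold lower number from compound 2 to compound 3 (0.34 log units; beyond the scatter). For compound 3 the estimated value is 22000 nM, with an expected range of 8000 nM to 60000 nM.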

Compound 3, half-maximal inhibitory concentration: > 250000 nM
Compound 3 gave a limit, no number; the forecaster's own chance of this, stated with the estimate: 15%; middle value at least 11-fold (1.05 log units) away from the limit.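

In this assay compound 3 gives only a limit of the assay, not a number: the limit of > 250000 nM in this assay, at which 1 of the 3 values shown sits. The earlier pair showed a change on the aromatic ring alone, whereas this position on an amide-type nitrogen tolerates extension poorly: with fluoro retained, ((3-fluorophenyl)carbamoyl)amino in place of 3-fluorophenyl gives an at least 13-fold higher number from compound 1 to compound 3 (1.14 log units; beyond the scatter). Against the hydroxy analogue, the same replacement gives an at least 5.2-fold higher number from compound 2 to compound 3 (0.71 log units; beyond the scatter).

As far as these compounds go, the full size of both steps remains open, as neither ends on a number. Also open, from the compounds shown here alone, is how an amine or a carboxylic acid on the aromatic ring, or a longer chain, would read.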